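This account rests on a few compounds, and the source may have more. Where it says the series, first, only, none or still open, it means among the compounds named here.

Measured compounds:
compound 1 `COc1cc(C(F)(F)F)cc(SC)c1C(=O)NC1(c2ccc(F)cc2)CCCN(C)C1` with 26 nM
compound 2 `COc1cc(C(F)(F)F)cc(SC)c1C(=O)NC1(c2ccc(F)cn2)CCCN(C)C1` with 180 nM

In an assay on cells for inhibition of sodium- and chloride-dependent glycine transporter 1 (Homo sapiens) (on this read-out lower numbers stand for an effect already at smaller amounts and higher numbers for an effect only at larger amounts of compound), compound 2 holds the highest of the two numbers; its nearest neighbour is compound 1, reached by a 6.9-fold higher number from compound 1 to compound 2 (0.84 log units; beyond the scatter). Compound 3 `COc1cc(C(F)(F)F)cc(SC)c1C(=O)NC1(c2ncccn2)CCCN(C)C1` is not yet measured. It differs from compound 2 by pyrimidin-2-yl in place of 5-fluoropyridin-2-yl on a saturated ring carbon. Within the data shown here, the only step that bears on this change is the exchange of the aryl group on that same saturated ring carbon, which gave a 6.9-fold higher number from compound 1 to compound 2 (0.84 log units; beyond the scatter). A further, modest rise is therefore expected for compound 3, about a 2.2-fold higher number from compound 2 to compound 3 (0.35 log units; beyond the scatter). Compound 3 is thus estimated at 400 nM, within a range from 120 nM to 1500 nM.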

Compound 3, half-maximal effective concentration: > 10000 nM
Compound 3: no number, only a limit (the forecaster's own chance of this, stated with the estimate: 5%); middle value at least 25-fold (1.39 log units) away from the limit.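

Compound 3 gives no number in this assay, only a limit: the limit of > 10000 nM in this assay, at which 1 of the 3 values shown sits.

Set against that limit, the exchange on the saturated ring carbon gives an at least 55-fold higher number from compound 2 to compound 3 (1.74 log units; beyond the scatter), and the full change from 4-fluorophenyl gives an at least 380-fold higher number from compound 1 to compound 3 (2.58 log units; beyond the scatter). Going by these compounds, the aryl group at this position therefore matters far more than the earlier modest step showed, and the true size of both new steps stays unknown.

The compounds shown leave open whether the lost fluorine or the added ring nitrogen carries this loss, as the two change together. They also leave open whether a chlorine atom or a nitrile on the pyrimidin-2-yl would restore a measurable value.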